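The source may report more compounds than this note shows. Statements on the series, on what has been measured and on what is new or still open speak of the compounds shown alone.

In an ADME assay on microsomes from liver (Mus musculus) for metabolic stability, read by LC-MS, using NADPH, with a stated time of 30 min, tested at 0.1 uM, in the presence of a further agent that is not named here (a lower number here means that less of the compound is left, a higher number that more of the compound is left), compound 1 `Nc1ncc(-c2ccc(C(=O)N3CCC(O)C3)cc2)nc1-c1ccc(C(F)(F)F)cc1` reads > 90% and this is a limit of the assay, not a number. Compound 2 `Nc1ccc(-c2nc(-c3ccc(S(=O)(=O)C4CC4)cc3)cnc2N)cn1` reads > 90% and this too is a limit, so its place in the series is not known as a number. The two measured compounds share one position at the limit of > 90% in this assay, at which 2 of the 2 values shown sit, and no number separates them.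

Compound 3 `N#Cc1ccc(-c2cnc(N)c(-c3ccc(N)nc3)n2)cc1` differs from compound 2 by cyano in place of cyclopropylsulfonyl on an aromatic carbon, para to a large group: cyano in place of cyclopropylsulfonyl on an aromatic carbon and the rest of the structure stays the same.

Among the compounds with values here, no measured step gives a size for such a change. The expected a number at least 2 percentage points lower from compound 2 to compound 3 (that floor lies within the scatter) is small, slightly downward if it shows at all, and is not expected to go beyond the scatter. That expectation rests on compound 2 with its limit > 90% and little else. A limit rather than a number is about as likely as not for the next reading. For compound 3 the estimated value is 88% with 70% to 100% as the expected range.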

Compound 3, percent of the compound remaining in the Mus musculus assay: > 90%
Compound 3 ended at the assay's limit; the forecaster's own chance of this, stated with the estimate: 50%; middle value at least 2 percentage points away from the limit.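

In the Mus musculus assay compound 2 reads > 90%, which is a limit of the assay and not a number. In the Mus musculus assay compound 3 reads > 90%, which is also a limit of the assay and not a number. Both compounds stand at the assay's limit, so no step between them can be read: the limit of > 90% in the Mus musculus assay, at which 3 of the 3 values shown sit.

In a physicochemical assay for solubility, read by HPLC, using the shake flask method, in phosphate buffer, with a stated time of 2 h, at pH 6.5 (a lower number here means a less soluble compound, a higher number a more soluble compound), compound 2 reads 13000 nM. In the physicochemical assay compound 3 reads < 5000 nM, which is a limit of the assay and not a number.

The compounds shown leave open how far cyano in place of cyclopropylsulfonyl moves the percent of compound remaining, and whether any compound in this series reads as a number rather than a limit in the Mus musculus assay.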